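From Methyl to Trifluoromethyl in a Cytotoxic Series

The source may hold more compounds than are shown below. What is called first, only, known or untested is meant among the compounds shown, and "the series" means these compounds.

Compound 1 `Cc1ccc(/C=C/C(=O)c2ccc(Nc3cc(C)nc4nc(SCc5nc6ccccc6[nH]5)nn34)cc2)cc1` gives 1520 nM
Compound 2 `Cc1cc(Nc2ccc(C(=O)/C=C/c3ccc4ccccc4c3)cc2)n2nc(SCc3cccc4ccccc34)nc2n1` gives 68 nM

A lower number means that less compound is needed for the same effect, so it marks stronger inhibition. In a functional assay on SW-620 cells (Homo sapiens) for cytotoxicity, read by MTT assay, with stated times of 4 h and 72 h, tested at 2 uM (on this read-out lower numbers stand for stronger inhibition and higher numbers for weaker inhibition), compound 1 has the higher of the two numbers at 1520 nM. Compound 2 gives 68 nM, a much lower number, and the gap lies beyond the usual scatter.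

Compound 3 `Cc1cc(Nc2ccc(C(=O)/C=C/c3ccc(C(F)(F)F)cc3)cc2)n2nc(SCc3nc4ccccc4[nH]3)nc2n1` differs from compound 1 in one place, with trifluoromethyl in place of methyl on an aromatic carbon. Within the data shown here, no two measured compounds differ in only one place, so the data show no direct precedent for this change. The estimate therefore starts from compound 1 at 1520 nM. In this assay, only a small shift toward a lower number is expected, and the estimated step of a 1.4-fold lower number from compound 1 to compound 3 (0.14 log units; within the scatter) stays within the scatter.

For compound 3 the expected value is 1100 nM, with an estimated range from 350 nM to 3000 nM.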

Compound 3, half-maximal inhibitory concentration: 1850 nM
For compound 3 the middle estimate is 1.7-fold (0.23 log units) below the measured one; the measured number falls inside the stated range.
By their numbers in this assay, from the lowest: compound 2; then compounds 1 and 3 (each within the scatter of the next).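

In this assay, the swap of 4-methylphenyl for 4-(trifluoromethyl)phenyl gives a 1.2-fold higher number from compound 1 to compound 3 (0.09 log units; within the scatter), so the two compounds cannot be told apart on this read-out. This is the only direct test of this change here, and it shows that in this setting, a methyl and a trifluoromethyl on this aromatic carbon give numbers that lie within the usual scatter of each other, even though the entering group has more heavy atoms. No measurement at hand offers an explanation for this result.

A single pair cannot show whether the same swap would give a similar result on a different parent compound. From the compounds shown here alone, whether an amine, a carboxylic acid or a longer chain on this same aromatic carbon would move the number beyond the scatter also remains open.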